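Swapping a Butylsulfanyl for a Benzyloxy on a Purine-like Core

The source may hold more compounds than are shown below. What is called first, only, known or untested is meant among the compounds shown, and "the series" means these compounds.

Measured compounds:
compound 1 `CCCCSc1nc(N)nc2c1ncn2/C=C1/CC1(CO)CO` — > 20000 nM
compound 2 `CC(C)CNc1nc(N)nc2c1ncn2/C=C1/CC1(CO)CO` — "not determined" (no result reported)
compound 3 `Nc1nc(N2CCCC2)c2ncn(/C=C3/CC3(CO)CO)c2n1` — "not determined" (no result reported)

Three compounds share one core and differ only in the group attached to it. In an ADME assay on MOLT-3 cells (Homo sapiens) for cytotoxicity, with a stated time of 7 days (a lower number here means that less compound is tolerated, a higher number that more compound is tolerated), compound 1 gives > 20000 nM, which is a limit of the assay and not a number. Compound 2 has no result recorded in this assay. Compound 3 likewise has no result recorded in this assay. So compound 1 stands alone, at the point described by the limit of > 20000 nM in this assay, at which 1 of the 3 values shown sits; there is no second number to compare it with and no measured step at all.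

The new compound is compound 4 `Nc1nc(OCc2ccccc2)c2ncn(/C=C3/CC3(CO)CO)c2n1`. It differs from compound 1 in one place: benzyloxy in place of butylsulfanyl on an aromatic carbon.

Going by the values given here, since no measured step exists, the expectation can rest only on compound 1. With compound 1 already at the limit in this assay, I expect no step beyond the usual scatter in this assay for compound 4, and I expect that compound 4 is most likely again reported as a limit rather than a number. My estimate for compound 4 is 20000 nM, with a range from 8000 nM to 50000 nM. The step that this estimate means, a number no higher from compound 1 to compound 4 (the limit leaves the size open), is expected to be none beyond the scatter.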

Compound 4, half-maximal cytotoxic concentration: > 20000 nM
Compound 4: only a limit was reported (the forecaster's own chance of this, stated with the estimate: 70%); the middle value lies on the limit itself.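

No step can be read between compound 1 and compound 4 in this assay, because each is reported only as a limit of the assay and not as a number: the limit of > 20000 nM in this assay, at which 2 of the 4 values shown sit. The compounds shown leave open where the true value of either compound lies, and whether benzyloxy in place of butylsulfanyl changes this read-out at all.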